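Swapping a phenyl for a dichloropyridinyl on the shared core

The source may hold more compounds than are shown below. What is called first, only, known or untested is meant among the compounds shown, and "the series" means these compounds.

Measured so far in a functional assay on Jurkat cells for inhibition of nuclear factor NF-kappa-B complex (Homo sapiens); on this read-out lower numbers stand for stronger inhibition and higher numbers for weaker inhibition:
- compound 1, `CCOC(=O)c1cnc(C(C)(C)C)nc1NN1C(=O)C=C(C)C1=O`: 1000 nM
- compound 2, `CCOC(=O)c1cnc(-c2ccccc2)nc1NN1C(=O)C=C(C)C1=O`: 100 nM

Compound 2 gives the lowest number of the two. Going by the values given here, the only change measured is the one from compound 1 to compound 2, where a 10-fold lower number from compound 1 to compound 2 (1.00 log units; beyond the scatter); this is the sole step that bears on what follows. Compound 3, `CCOC(=O)c1cnc(-c2cc(Cl)nc(Cl)c2)nc1NN1C(=O)C=C(C)C1=O`, is reached from compound 2 by 2,6-dichloropyridin-4-yl in place of phenyl on an aromatic carbon. The aromatic ring that distinguished compound 2 from compound 1 is kept, so the gain seen in this assay from compound 1 to compound 2 is expected to carry over. Among the compounds with values here, no measured step shows what the two chlorines and the ring nitrogen do, so there is no basis for expecting a step beyond the scatter in either direction. Compound 3 is therefore estimated at 150 nM, between 40 nM and 600 nM, an expected 1.5-fold higher number from compound 2 to compound 3 (0.18 log units; within the scatter).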

Compound 3, half-maximal inhibitory concentration: 2000 nM
Compound 3: middle estimate off by 13-fold (1.12 log units), on the low side; measured number outside the range, above it.
By their numbers in this assay, from the lowest: compound 2; then compounds 1 and 3 (each within the scatter of the next).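

In this assay, the group at this position matters beyond simply being an aromatic ring: replacing phenyl with 2,6-dichloropyridin-4-yl gives a 20-fold higher number from compound 2 to compound 3 (1.30 log units; beyond the scatter). Set against the tert-butyl group, the same ring gives a 2.0-fold higher number from compound 1 to compound 3 (0.30 log units; within the scatter), so the advantage phenyl showed over tert-butyl is not kept by this aromatic ring. No measurement shown here explains the loss.

The ring nitrogen and the two chlorines enter together, so their separate contributions cannot be read from these compounds. Going by these compounds alone, an unsubstituted pyridin-4-yl and a dichlorophenyl group would each carry only one part of the change, and how either would fare at this position remains open.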